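Dichlorobenzyl Thioether Triazoles in a Liver Cell Toxicity Test

The source may hold more compounds than are shown below. What is called first, only, known or untested is meant among the compounds shown, and "the series" means these compounds.

compound 1 `Cn1c(SCc2ccccc2)nnc1-c1cc([N+](=O)[O-])cc([N+](=O)[O-])c1`: > 30000 nM
compound 2 `Cn1c(SCc2ccc(Cl)cc2)nnc1-c1cc([N+](=O)[O-])cc([N+](=O)[O-])c1`: > 30000 nM
compound 3 `O=[N+]([O-])c1cc(-c2nnc(SCc3ccc(Cl)cc3)n2Cc2ccccc2)cc([N+](=O)[O-])c1`: > 30000 nM

All three measured compounds were run in an ADME assay on HepG2 cells (Homo sapiens) for cytotoxicity, with a stated time of 48 h; a lower number here means a stronger inhibitor, a higher number a weaker inhibitor. In this assay compound 1 gives > 30000 nM, which is a limit of the test rather than a number. Compound 2 gives > 30000 nM, again a limit. Compound 3 gives > 30000 nM, also a limit. Both a step that the two limits leave unreadable from compound 1 to compound 2 and a step that the two limits leave unreadable from compound 2 to compound 3 follow, because all three values sit at the limit of > 30000 nM in this assay, at which 3 of the 3 values shown sit.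

The change from compound 1 to compound 2 is chloro in place of hydrogen on an aromatic carbon. Compound 4 `O=[N+]([O-])c1cc(-c2nnc(SCc3ccc(Cl)c(Cl)c3)n2Cc2ccccc2)cc([N+](=O)[O-])c1` has not been measured; it differs from compound 3 by chloro in place of hydrogen on an aromatic carbon, the same kind of change, though here the chloro enters ortho to a chloro group and meta to a large group, whereas in compound 2 it sits para to a large group. The difference between the core of compound 1 and the core of compound 3 is not broken down here. Given that the three measured values sit at the limit of > 30000 nM in this assay, at which 3 of the 3 values shown sit, the step expected in this assay is a step that the limit leaves unreadable from compound 3 to compound 4. Compound 4 is estimated at 40000 nM, likely between 15000 nM and 120000 nM.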

Compound 4, half-maximal inhibitory concentration: > 30000 nM
Compound 4: a limit, no number (the forecaster's own chance of this, stated with the estimate: 85%); the middle value is on the limit's open side.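

In this assay compound 4 gives > 30000 nM as a limit of the test, not a number. No step from compound 3 to compound 4 can be read, because both values are limits: the limit of > 30000 nM in this assay, at which 4 of the 4 values shown sit.

Going by these compounds, how strongly any of the four compounds acts in this assay stays open, and so does what the added chloro changes.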